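Swapping a Fluorophenyl Arm for a Pyrazole Ring

The source may hold more compounds than are shown below. What is called first, only, known or untested is meant among the compounds shown, and "the series" means these compounds.

In a functional assay on HOS cells (Homo sapiens) for inhibition, with a stated time of 72 h (a lower number here means a stronger inhibitor, a higher number a weaker inhibitor), compound 1 `NC1CCC(Nc2nc(NCc3ccc(-c4ccccc4)cc3)c3ncn(C4CCCC4)c3n2)CC1` gives 290 nM. In this assay compound 2 `NC1CCC(Nc2nc(NCc3ccc(-c4cccc(F)c4)cc3)c3ncn(C4CCCC4)c3n2)CC1` gives 211 nM. In this assay compound 3 `NC1CCC(Nc2nc(NCc3ccc(-c4ccsc4)cc3)c3ncn(C4CCCC4)c3n2)CC1` gives 120 nM.

Compound 2 holds the second highest of the three numbers: the step of a 1.4-fold lower number from compound 1 to compound 2 (0.14 log units; within the scatter) and the step of a 1.8-fold lower number from compound 2 to compound 3 (0.25 log units; within the scatter) both stay within the scatter. Compound 4 `NC1CCC(Nc2nc(NCc3ccc(-n4cccn4)cc3)c3ncn(C4CCCC4)c3n2)CC1` differs from compound 2 in one place: 1H-pyrazol-1-yl in place of 3-fluorophenyl on an aromatic carbon. Going by the values given here, the nearest precedent is a 1.8-fold lower number from compound 2 to compound 3 (0.25 log units; within the scatter), where a five-membered aromatic ring also replaced 3-fluorophenyl, and a 2.4-fold lower number from compound 1 to compound 3 (0.38 log units; beyond the scatter), a modest change. Among the compounds with values here, no measured step brings in 1H-pyrazol-1-yl itself, so the step of a 1.0-fold higher number from compound 2 to compound 4 (0.02 log units; within the scatter) is expected to lie within the scatter or only modestly beyond it. Compound 4 is estimated at 220 nM, with a range from 90 nM to 550 nM.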

Compound 4, half-maximal inhibitory concentration: 103 nM
The estimate for compound 4 lay 2.1-fold (0.33 log units) above the measured number; measured number inside the range.
By their numbers in this assay, from the lowest: compounds 4, 3, 2 and 1 (each within the scatter of the next, the first and the last beyond it).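

Going by these compounds alone, the 1H-pyrazol-1-yl ring is the first arm here to give a step beyond the scatter from the 3-fluorophenyl arm, with a 2.0-fold lower number from compound 2 to compound 4 (0.31 log units; beyond the scatter) in this assay and a 2.8-fold lower number from compound 1 to compound 4 (0.45 log units; beyond the scatter) from the plain phenyl arm also beyond it. Against the sulfur-containing ring, a 1.2-fold lower number from compound 3 to compound 4 (0.07 log units; within the scatter) stays within the scatter, so a five-membered aromatic ring with two nitrogens serves at this position as well as thiophen-3-yl does. Nothing measured here explains this result. Still open, as far as these compounds go, is how a pyridine ring, an imidazole ring or a simple amine would behave at this position.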